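This account rests on a few compounds, and the source may have more. Where it says the series, first, only, none or still open, it means among the compounds named here.

Measured in a functional assay on NIH3T3 cells for agonist activity at Urotensin-2 receptor (Homo sapiens), with a stated time of 5 days; on this read-out lower numbers stand for an effect already at smaller amounts and higher numbers for an effect only at larger amounts of compound:
compound 1 `Cc1ccc(C(CCN(C)C)NC(=O)CCc2ccccc2)cc1` gives 4570 nM
compound 2 `Cc1ccc(C(CCN(C)C)NC(=O)CCc2ccc(C(F)(F)F)cc2)cc1` gives 2290 nM
compound 3 `Cc1ccc(C(CCN(C)C)NC(=O)/C=C/c2ccccc2)cc1` gives 1550 nM

Compound 4 `Cc1ccc(C(CCN(C)C)NC(=O)/C=C/c2ccc(C(F)(F)F)cc2)cc1` is not yet measured in this assay.

Compounds 1 and 2 share one core, compounds 3 and 4 another. The difference between the two cores is 2-phenylethenyl in place of phenethyl on a carbonyl carbon; that change gave a 2.9-fold lower number from compound 1 to compound 3 (0.47 log units; beyond the scatter). On the first core, trifluoromethyl in place of hydrogen on an aromatic carbon gave a 2.0-fold lower number from compound 1 to compound 2 (0.30 log units; within the scatter). The change now to be made on the second core is trifluoromethyl in place of hydrogen on an aromatic carbon; its place is described in the same words as before, so it is the same change carried from one core to the other. Compound 3 has the lowest number of the three measured, but its gap to compound 2 lies within the scatter, so no order between those two is claimed; only the gap from compound 1 to compound 3 is beyond the scatter.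

The expectation for compound 4 rests on a single precedent. For compound 4 the expected step in this assay is a 1.9-fold lower number from compound 3 to compound 4 (0.29 log units; within the scatter), set beside the earlier 2.0-fold lower number from compound 1 to compound 2 (0.30 log units; within the scatter), with the caution that the earlier step was itself within the scatter and that nothing shows how the change behaves on the second core. The estimate for compound 4 in this assay is 800 nM, with a range from 400 nM to 2000 nM.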

Compound 4, half-maximal effective concentration: 437 nM
The estimate for compound 4 lay 1.8-fold (0.26 log units) above the measured number, and the stated range covers the measured number.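

In this assay, trifluoromethyl in place of hydrogen on an aromatic carbon of the second core gives a 3.5-fold lower number from compound 3 to compound 4 (0.55 log units; beyond the scatter). Set beside the earlier step, this gives one pair for the series, and the two steps cannot be told apart: the same change on two cores in this assay, a 2.0-fold lower number (0.30 log units; within the scatter) from compound 1 to compound 2 and a 3.5-fold lower number (0.55 log units; beyond the scatter) from compound 3 to compound 4, 1.8-fold (0.25 log units) apart, within the scatter of two such steps. The change therefore carries from one core to the other with the same direction and a compatible size, but although only the new step lies beyond the scatter, this does not show that the change acts more strongly on the second core, and one pair of cores gives no general rule for the series or any reason for the steps.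

Still open, as far as these compounds go, is whether a chlorine atom, a methoxy group or a nitrile in the place of trifluoromethyl would give steps of similar size on these two cores. Also open, from the compounds shown here alone, is whether the trifluoromethyl step holds when the dimethylamino group gives way to a primary amine or a carboxylic acid, or when a longer chain replaces the phenethyl or 2-phenylethenyl group on the carbonyl carbon.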